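The source may hold more compounds than are shown below. What is called first, only, known or untested is meant among the compounds shown, and "the series" means these compounds.

- Compound 1 `Cc1cncn1CC#CCN1CCNC1=O` gives 66 mg/kg
- Compound 2 `CN1CCN(CC#CCn2ccnc2)C1=O` gives > 100 mg/kg

In a functional assay on the whole organism for antagonist activity, with Mus musculus as the target (a lower number here means that less compound is needed, a higher number that more compound is needed for the effect), compound 2 stands at > 100 mg/kg and this is a limit of the assay, not a number. Going by these compounds, its true place on the scale therefore remains open. For the measured compounds named here, compound 1 gives 66 mg/kg in this assay and so supplies the only actual number so far.

Compound 3 `Cc1cncn1CC#CCN1CCN(C)C1=O` departs from compound 2 by a single change methyl in place of hydrogen on an aromatic carbon and it is methyl in place of hydrogen on an aromatic carbon. Going by the values given here, no step between measured compounds differing in one place is available, so the data give no direct size for this change. Among the compounds with values here, a modest move toward a lower dose is expected, and the one measured number, compound 1 at 66 mg/kg in this assay, sets the scale for that expectation. The expected change is an at least 1.6-fold lower number from compound 2 to compound 3 (0.22 log units; that floor lies within the scatter) and it may not clear the usual scatter. The assay may also report only a limit again. For compound 3 the estimated value is 60 mg/kg with an expected range from 20 mg/kg to 150 mg/kg in this assay as the read-out.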

Compound 3, dose for half-maximal effect: > 100 mg/kg
Compound 3: only a limit was reported (the forecaster's own chance of this, stated with the estimate: 35%); middle value at least 1.6-fold (0.22 log units) from the limit.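

In this assay, methyl in place of hydrogen on an aromatic carbon of the five-membered aromatic ring does not yield a number: compound 3 gives > 100 mg/kg, which is a limit of the assay. The steps that compare limits cannot be read, so neither the size nor the direction of this change on the aromatic carbon is known, and the readings now share one ceiling: the limit of > 100 mg/kg in this assay, at which 2 of the 3 values shown sit.

For the compounds shown here, the one readable step concerns the other position, with methyl in place of hydrogen on an amide-type nitrogen in a ring: it is an at least 1.5-fold higher number from compound 1 to compound 3 (0.18 log units; that floor lies within the scatter), and it gives only a floor, so the true size of the step remains unknown.

Going by these compounds, whether methyl on the aromatic carbon helps, harms or does nothing stays open, as does whether compound 1, with its amide hydrogen, keeps a readable value when the ring methyl is removed. Also open, on these data alone, is what an ethyl group on that amide-type nitrogen, or a longer chain in place of the methyl on the aromatic carbon, would give in this assay.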